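The compounds below may be only part of what the source reports. "The series", "measured", "known", "first", "only" and "open" are said of these compounds alone.

Measured so far: compound 1 `CCOC(=O)CCCCOc1ccc2c(=O)c(-c3ccc(O)cc3)coc2c1` with 240 nM and compound 2 `C=CCOc1ccc2c(=O)c(-c3ccc(O)cc3)coc2c1` with 180 nM.

In an assay (Cricetulus griseus) for inhibition of aldehyde dehydrogenase, mitochondrial (Homo sapiens) (on this read-out higher numbers stand for weaker inhibition and lower numbers for stronger inhibition), compound 2 shows the lowest of the two numbers, its nearest neighbour being compound 1, at a gap within the scatter a 1.3-fold lower number from compound 1 to compound 2 (0.12 log units; within the scatter). Compound 3 `O=C(O)CCCCOc1ccc2c(=O)c(-c3ccc(O)cc3)coc2c1` is still to be measured. It differs from compound 2 by 3-carboxypropyl in place of vinyl on a saturated chain carbon bound to an oxygen on an aromatic ring. Among the compounds with values here, the single measured step at this place, a 1.3-fold lower number from compound 1 to compound 2 (0.12 log units; within the scatter), lay within the scatter; no step shows 3-carboxypropyl against 3-(ethoxycarbonyl)propyl. One therefore expects no step beyond the scatter, a 1.4-fold higher number from compound 2 to compound 3 (0.14 log units; within the scatter). Compound 3 is estimated at 250 nM, within 80 nM to 800 nM.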

Compound 3, half-maximal inhibitory concentration: 100 nM
For compound 3 the middle estimate is 2.5-fold (0.40 log units) above the measured one; measured number inside the range.
By their numbers in this assay, from the lowest: compounds 3, 2 and 1 (each within the scatter of the next, the first and the last beyond it).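

Hydrogen in place of ethyl on an oxygen next to a carbonyl group gives a 2.4-fold lower number from compound 1 to compound 3 (0.38 log units; beyond the scatter) in this assay and is the first step at this position to pass beyond the scatter, though only modestly. Against vinyl, the 3-carboxypropyl group shows a 1.8-fold lower number from compound 2 to compound 3 (0.26 log units; within the scatter) and so cannot be told apart from it. Nothing available explains either step.

Whether the carboxylic acid must stand at this chain end stays open, since an amide or an amine there is not among these compounds. Going by these compounds, how a shorter or longer chain carrying the acid would compare also stays open.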